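Working notes: from compound 2 to compound 3

The source may report more compounds than this note shows. Statements on the series, on what has been measured and on what is new or still open speak of the compounds shown alone.

Measured so far: compound 1 `O=C1N(Cc2ccc(Br)cc2)c2ccc(Cl)cc2C1(O)Cc1nnn[nH]1` gives 87900 nM in a functional assay on PC-3 cells (Homo sapiens) for antiproliferative activity, read by MTT assay, with a stated time of 48 h; a lower number here means a stronger inhibitor, a higher number a weaker inhibitor. Compound 2 `CCN1C(=O)C(O)(Cc2nnn[nH]2)c2cc(Br)ccc21` gives > 100000 nM in this assay.

Compound 2 stands only at a limit of this assay, not at a number, as the limit of > 100000 nM in this assay, at which 1 of the 2 values shown sits, shows. Compound 3 `O=C1N(Cc2ccc(Br)cc2)c2ccc(Br)cc2C1(O)Cc1nnn[nH]1` differs from compound 2 by 4-bromophenyl in place of methyl on a saturated chain carbon bound to an amide-type nitrogen in a ring. Among the measured compounds shown here, no step between measured compounds is recorded, so its size cannot be read directly; compound 1 carries the same 4-bromobenzyl and does give a number, 87900 nM, so a step toward measurable inhibition is expected. The expected step is an at least 1.2-fold lower number from compound 2 to compound 3 (0.09 log units; that floor lies within the scatter). Compound 3 is estimated at 80000 nM, within 40000 nM to 160000 nM.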

Compound 3, half-maximal inhibitory concentration: > 100000 nM
Compound 3: a limit, no number; the forecaster's own chance of this, stated with the estimate: 40%; at least 1.2-fold (0.09 log units) between middle value and limit.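

With 4-bromophenyl in place of methyl on a saturated chain carbon bound to an amide-type nitrogen in a ring, the step between compound 2 and compound 3 cannot be read, so this change shows no measurable gain in this assay. Bromo in place of chloro on an aromatic carbon gives an at least 1.1-fold higher number from compound 1 to compound 3 (0.05 log units; that floor lies within the scatter), so the 4-bromobenzyl group does not by itself secure a number. Most of this short series thus stands at a limit, not a number: the limit of > 100000 nM in this assay, at which 2 of the 3 values shown sit.

From the compounds shown here alone, whether a 4-aminobenzyl group or a longer chain in place of 4-bromobenzyl would give a number clear of this limit stays open.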